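The compounds below may be only part of what the source reports. "The series", "measured", "known", "first", "only" and "open" are said of these compounds alone.

Measured so far in an ADME assay for solubility; a higher number here means a more soluble compound, a lower number a less soluble compound:
- compound 1 `Cc1c(O)c(=O)ccn1CCCc1cc(C(C)(C)C)c(O)c(C(C)(C)C)c1`: < 100 ug/mL, a limit of this assay
- compound 2 `Cc1c(OC(=O)CCN)c(=O)ccn1CCCc1cc(C(C)(C)C)c(O)c(C(C)(C)C)c1`: > 20000 ug/mL
- compound 3 `Cc1c(OC(=O)c2ccc(N)cc2)c(=O)ccn1CCCc1cc(C(C)(C)C)c(O)c(C(C)(C)C)c1`: < 100 ug/mL

Among the measured compounds shown here, compound 2 is the one compound whose value is not a number but a limit, (the limit of > 20000 ug/mL in this assay, at which 1 of the 3 values shown sits). Compound 3 stands at the other limit, (the limit of < 100 ug/mL in this assay, at which 2 of the 3 values shown sit), where compound 1 also sits; of compound 3 no number is known, only that it lies at that limit.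

The next compound, compound 4 `CC(=O)Oc1c(C)n(CCCc2cc(C(C)(C)C)c(O)c(C(C)(C)C)c2)ccc1=O`, differs from compound 3 in one place: methyl in place of 4-aminophenyl on a carbonyl carbon.

For the measured compounds named here, two measured steps bear on this. The change from a hydrogen on the phenolic oxygen to the (2-aminoethyl)carbonyl ester gave an at least 200-fold higher number from compound 1 to compound 2 (2.30 log units; beyond the scatter), whereas the step of an at least 200-fold lower number from compound 2 to compound 3 (2.30 log units; beyond the scatter) took the value back to the lower limit. The step that the two limits leave unreadable from compound 1 to compound 3 is unreadable between the two limits. The acetyl ester of compound 4 carries no amine and no aromatic ring in the ester group, and among the measured compounds only the amine-bearing ester of compound 2 reached the upper limit.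

Compound 4 is therefore expected to stay near the lower limit; the estimated step is a step that the limit leaves unreadable from compound 3 to compound 4, with compound 4 expected at 50 ug/mL (range 10 ug/mL to 250 ug/mL), most likely reported again only as a limit.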

Compound 4, solubility: < 100 ug/mL
Compound 4: a limit, no number; the forecaster's own chance of this, stated with the estimate: 65%; the middle value lies beyond the limit too.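

In this assay compound 4 gives < 100 ug/mL, which is a limit of the assay and not a number. The new pair isolates the aminomethyl on the saturated chain of the ester group, and hydrogen in its place gives an at least 200-fold lower number from compound 2 to compound 4 (2.30 log units; beyond the scatter), so an ester on this oxygen is not enough by itself to hold the value of compound 2, and the difference between these two esters lies in that one place. The steps from compound 1 to compound 4 and from compound 3 to compound 4 cannot be read, and the hydrogen, the (4-aminophenyl)carbonyl and the acetyl on this oxygen now all stand at the same limit: the limit of < 100 ug/mL in this assay, at which 3 of the 4 values shown sit.

As far as these compounds go, how far compound 1, compound 3 and compound 4 differ from one another remains open, as all three are known only as limits. Also open, from the compounds shown here alone, is whether a carboxylic acid in the ester group, a tertiary amine in place of the primary amine, or a longer chain carrying the amine would give a value like that of compound 2.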